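Adding a Methyl to the Amide Nitrogen of Compound 2

The source may report more compounds than this note shows. Statements on the series, on what has been measured and on what is new or still open speak of the compounds shown alone.

Compound 1, `Cc1ncccc1-c1cnc(NCc2c(F)ccc3c2CCO3)c2cn[nH]c(=O)c12`, gives 4.6 uL/min in an ADME assay on cells (Hepatocyte, Homo sapiens) for metabolic stability, read by HPLC, with a stated time of 30 min, tested at 1 uM; a higher number here means faster removal of the compound, a lower number slower removal.
Compound 2, `CNC(=O)c1ccc(-c2cnc(NCc3c(F)ccc4c3CCO4)c3cn[nH]c(=O)c23)c(C)n1`, gives 3 uL/min in this assay.

Within the data shown here, compound 2 stands lowest of the two numbers measured so far, but the only measured step, a 1.5-fold lower number from compound 1 to compound 2 (0.19 log units; within the scatter), lies within the scatter, so the two compounds cannot be told apart on this read-out.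

Compound 3, `Cc1nc(C(=O)N(C)C)ccc1-c1cnc(NCc2c(F)ccc3c2CCO3)c2cn[nH]c(=O)c12`, is not yet measured. It differs from compound 2 by methyl in place of hydrogen on an amide-type nitrogen. Among the measured compounds shown here, the one measured step, a 1.5-fold lower number from compound 1 to compound 2 (0.19 log units; within the scatter), concerns a change on an aromatic carbon and was itself within the scatter; no measured pair shows a methyl replacing hydrogen on an amide-type nitrogen. With nothing pointing either way, the expectation for compound 3 is a step no larger than the scatter, a 1.2-fold higher number from compound 2 to compound 3 (0.07 log units; within the scatter), in no particular direction. Compound 3 is therefore estimated at 3.5 uL/min, with a range from 1.5 uL/min to 8 uL/min.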

Compound 3, intrinsic clearance in a liver preparation (reported as CLH), per the amount of preparation that the assay uses: < 1.3 uL/min
Compound 3 gave a limit, no number; the forecaster's own chance of this, stated with the estimate: 5%; middle value at least 2.6-fold (0.43 log units) away from the limit.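

In this assay compound 3 gives a limit and not a number: the limit of < 1.3 uL/min in this assay, at which 1 of the 3 values shown sits.

Methyl in place of hydrogen on the amide-type nitrogen gives an at least 2.3-fold lower number from compound 2 to compound 3 (0.36 log units; beyond the scatter), so at this position a change of one heavy atom moves the read-out clearly. Dimethylcarbamoyl in place of hydrogen on the aromatic carbon gives an at least 3.5-fold lower number from compound 1 to compound 3 (0.54 log units; beyond the scatter), whereas methylcarbamoyl at that carbon could not be told apart from hydrogen.

As far as these compounds go, the true size of both steps stays open, since each rests on a limit. Also open, from the compounds shown here alone, is whether an ethyl group or a longer chain on the same nitrogen, or a carboxylic acid in place of the amide, would give a number as low, so these three compounds support no wider rule about this position.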